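Oxetan-3-yl on the sulfonyl sulfur of compound 1

This account rests on a few compounds, and the source may have more. Where it says the series, first, only, none or still open, it means among the compounds named here.

In an ADME assay on microsomes from liver (Mus musculus) for metabolic stability, read by LC-MS, with a stated time of 40 min, tested at 0.5 uM (on this read-out higher numbers stand for fast clearance and lower numbers for slow clearance), compound 1 (`CC(C)(CO)S(=O)(=O)c1cccc(NC(=O)c2cccnc2N2CCC3(CC2)CC3)c1`) gives > 399 mL.min-1.g-1 as a limit of the assay and not as a number. Compound 2 (`CC(C)(C)NS(=O)(=O)c1cccc(NC(=O)c2ccc(NC(C)(C)CO)cc2N2CCC3(CC2)CC3)n1`) gives > 399 mL.min-1.g-1 and this too is only a limit. Among the measured compounds shown here, the series so far therefore offers the limit of > 399 mL.min-1.g-1 in this assay, at which 2 of the 2 values shown sit, and no clearance that can be read as a number.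

Compound 3 (`O=C(Nc1cccc(S(=O)(=O)C2COC2)c1)c1cccnc1N1CCC2(CC1)CC2`) keeps the core of compound 1 and carries oxetan-3-yl in place of 1-(hydroxymethyl)-1-methylethyl on a sulfonyl sulfur. For the measured compounds named here, no two measured compounds differ in one place, so no measured step guides the size of this change. The step expected is an at least 1.2-fold lower number from compound 1 to compound 3 (0.09 log units; that floor lies within the scatter) in this assay and the expected direction is toward slower clearance, although a result at the same limit would fit the data equally well. For compound 3 the estimate is 320 mL.min-1.g-1 with an expected range from 140 mL.min-1.g-1 to 500 mL.min-1.g-1 and a substantial expected chance that only a limit is reported.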

Compound 3, intrinsic clearance in microsomes: 385 mL.min-1.g-1
The estimate for compound 3 lay 1.2-fold (0.08 log units) below the measured number, and the stated range covers the measured number.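

In this assay compound 3 gives 385 mL.min-1.g-1, the first clearance in the series that can be read as a number, so this place on the sulfonyl sulfur now has one measured reading. Oxetan-3-yl in place of 1-(hydroxymethyl)-1-methylethyl gives an at least 1.0-fold lower number from compound 1 to compound 3 (0.01 log units; that floor lies within the scatter), which is only a floor: the true size of the step stays unknown, and nothing beyond the scatter is shown for this change. The rest of the series gives no further number to set beside this reading: the limit of > 399 mL.min-1.g-1 in this assay, at which 2 of the 3 values shown sit.

Going by these compounds, it remains open whether another group on the sulfonyl sulfur, such as a simple methyl, a cyclopropyl or a chain ending in an amine or a carboxylic acid, would give a number clearly apart from that of compound 3. On these data alone, it also remains open how much of the clearance depends on the group on the sulfonyl sulfur and how much on the shared core, and only pairs that differ in one place on that core could separate the two.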